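From tert-butyl to isopropyl on the shared core

A few compounds are considered here, and "the series" means these few. Any claim that something is new, unique, unknown or untested is made for them only; others in the source may bear on it.

Measured in an ADME assay on L6 cells (Rattus norvegicus) for cytotoxicity, read by resazurin assay, with a stated time of 70 h; a lower number here means that less compound is needed, a higher number that more compound is needed for the effect:
compound 1 `CC(=O)Nc1cnc2[nH]c(=O)n([C@H]3CC[C@H](C(C)C)CC3)c(=O)c2c1`: 32000 nM
compound 2 `CC(C)(C)[C@H]1CC[C@H](n2c(=O)[nH]c3ncc(N)cc3c2=O)CC1`: 63000 nM

Compound 2 (63000 nM) lies within the usual scatter of compound 1 (32000 nM), so the two numbers cannot be told apart. Compound 3 (`CC(C)[C@H]1CC[C@H](n2c(=O)[nH]c3ncc(N)cc3c2=O)CC1`) has not yet been measured. It carries hydrogen in place of methyl on a saturated chain carbon bound to two saturated chain carbons and a saturated ring carbon, which turns tert-butyl into isopropyl. Among the measured compounds shown here, no measured pair isolates this change, so the expectation is weakly grounded. Compound 1, which also carries isopropyl, gives 32000 nM but differs elsewhere. In this assay no shift beyond the scatter is expected, and no firm direction. The expected step is small (a 1.1-fold lower number from compound 2 to compound 3 (0.06 log units; within the scatter)). The estimated value for compound 3 is 55000 nM (expected range 25000 nM to 110000 nM).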

Compound 3, half-maximal effective concentration: 46000 nM
For compound 3 the middle estimate is 1.2-fold (0.08 log units) above the measured one; the range from low to high includes it.
By their numbers in this assay, from the lowest: compounds 1, 3 and 2 (each within the scatter of the next).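

In this assay, the tert-butyl to isopropyl change on the saturated chain carbon now has a measured pair of its own, and it stays within the scatter (a 1.4-fold lower number from compound 2 to compound 3 (0.14 log units; within the scatter)). With isopropyl held constant, hydrogen in place of acetyl on the nitrogen on the aromatic ring also stays within the scatter (a 1.4-fold higher number from compound 1 to compound 3 (0.16 log units; within the scatter)), so neither single change separates these compounds in this assay. Nothing measured here offers an explanation for either step.

Still open, going by these compounds, is whether ethyl or phenyl at the isopropyl site would stay within the scatter of compound 3. The same question applies to a longer acyl chain such as butanoyl, or a methanesulfonyl group, on that nitrogen.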